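A few compounds are considered here, and "the series" means these few. Any claim that something is new, unique, unknown or untested is made for them only; others in the source may bear on it.

Working notes on the series.

Compound 1 `Cc1ccc(-n2cc(-c3ccc(CN4CCN(C)CC4)c(C(F)(F)F)c3)nn2)cc1Nc1nccc(-c2cccnc2)n1` is the stronger of the two compounds measured in a functional assay on HL-60 cells (Homo sapiens) for inhibition, read by MTT assay, with a stated time of 72 h (on this read-out lower numbers stand for stronger inhibition and higher numbers for weaker inhibition), where compound 1 gives 20 nM. The other measured compound, compound 2 `Cc1ccc(-n2cc(-c3cc(C(F)(F)F)cc(C(F)(F)F)c3)nn2)cc1Nc1nccc(-c2cccnc2)n1`, carries two trifluoromethyl groups on the pendant ring and no amine-bearing side chain; in this assay compound 2 gives 1600 nM, a gap from compound 1 that lies well beyond the scatter. For the measured compounds named here, compound 2 is not a single-point neighbour of compound 1, so its number only shows what a different pendant ring does and sets no step for the change considered here.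

The next compound, compound 3 `Cc1ccc(-n2cc(-c3ccc(C)c(C(F)(F)F)c3)nn2)cc1Nc1nccc(-c2cccnc2)n1`, keeps the shared core of compound 1 and differs only in the side chain: hydrogen in place of 4-methylpiperazin-1-yl on a saturated chain carbon bound to an aromatic carbon. The methyl that remains, together with the trifluoromethyl group, is all that stays on that ring.

Nothing measured in the series isolates this change. Going by the values given here, because compound 1 reaches 20 nM with the 4-methylpiperazin-1-yl group in place, and the only compound without such a chain, compound 2, sits at 1600 nM, the removal is expected to weaken inhibition by a step of a 7.5-fold higher number from compound 1 to compound 3 (0.88 log units; beyond the scatter), beyond the scatter but well short of the gap to compound 2. Compound 3 is accordingly estimated at 150 nM, with a range from 40 nM to 600 nM.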

Compound 3, half-maximal inhibitory concentration: > 30000 nM
Compound 3: only a limit was reported (the forecaster's own chance of this, stated with the estimate: 5%); at least 200-fold (2.30 log units) between middle value and limit.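

For the compounds shown here, the first single-place step concerns the 4-methylpiperazin-1-yl group: with hydrogen in its place on a saturated chain carbon bound to an aromatic carbon, this assay gives an at least 1500-fold higher number from compound 1 to compound 3 (3.17 log units; beyond the scatter), which is beyond the scatter and marked as large. This shows that, on the shared core of compound 1, inhibition at this position depends heavily on the 4-methylpiperazin-1-yl group, and that the methyl and trifluoromethyl groups left on the ring do not keep compound 3 within the measured range. The value of compound 3 is a limit of the assay and not a number, so the step has no upper end, and its size is known only from one side: the limit of > 30000 nM in this assay, at which 1 of the 3 values shown sits.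

The compounds shown leave open whether the piperazine ring itself is needed or whether a simpler amine, such as dimethylamino, or a morpholine ring on the same chain carbon would hold inhibition in this assay. They also leave open how much the methyl on the far nitrogen of the piperazine contributes, since a piperazine carrying hydrogen there is not among them.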